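This account rests on a few compounds, and the source may have more. Where it says the series, first, only, none or still open, it means among the compounds named here.

In a functional assay on MCF7 cells (Homo sapiens) for antiproliferative activity, read by CellTiter-Glo, with a stated time of 5 days (a lower number here means a stronger inhibitor, a higher number a weaker inhibitor), compound 1 `CC1=C(c2cccc(S(C)(=O)=O)c2)C(c2ccc(OC[C@H](C)N3CC[C@@H](C)C3)cc2)Oc2ccc(O)cc21` gives 4.3 nM and compound 2 `CC1=C(c2cccc(C#N)c2)C(c2ccc(OC[C@H](C)N3CC[C@@H](C)C3)cc2)Oc2ccc(O)cc21` gives 2.6 nM. These two values lie within the scatter of each other, so the numbers cannot separate compound 2 from compound 1. Compound 3 `CC1=C(c2ccc(O)cc2)C(c2ccc(OC[C@H](C)N3CC[C@@H](C)C3)cc2)Oc2ccc(O)cc21`, not yet measured, differs from compound 2 by one swap: 4-hydroxyphenyl in place of 3-cyanophenyl on a double-bonded ring carbon. In words, 4-hydroxyphenyl stands in place of 3-cyanophenyl on a double-bonded ring carbon. Going by the values given here, the only measured step that bears on this is a 1.7-fold lower number from compound 1 to compound 2 (0.22 log units; within the scatter), a change of cyano for methylsulfonyl on an aromatic carbon, and it stayed within the scatter. Among the compounds with values here, one small step is thin evidence, and no measured compound here carries the new group. No shift beyond the scatter is therefore expected in this assay. The estimated change is a 1.0-fold lower number from compound 2 to compound 3 (0.02 log units; within the scatter). Compound 3 is expected at about 2.5 nM, within an estimated range of 0.9 nM to 7 nM.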

Compound 3, half-maximal inhibitory concentration: 0.1 nM
Estimate against measurement, compound 3: 25-fold (1.40 log units) above; the whole stated range lies above it.
By their numbers in this assay, from the lowest: compound 3; then compounds 2 and 1 (each within the scatter of the next).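

In this assay, the group on this double-bonded ring carbon proves able to move the number far beyond the scatter: 4-hydroxyphenyl in place of 3-cyanophenyl gives a 26-fold lower number from compound 2 to compound 3 (1.41 log units; beyond the scatter), and 4-hydroxyphenyl in place of 3-(methylsulfonyl)phenyl gives a 43-fold lower number from compound 1 to compound 3 (1.63 log units; beyond the scatter). The earlier exchange of methylsulfonyl for cyano stayed within the scatter, so compound 1 and compound 2 gave no sign of this sensitivity. Nothing measured here explains the large drop.

The names 3-cyanophenyl and 4-hydroxyphenyl differ in both the group and its number on the phenyl ring, so these compounds cannot separate the effect of the hydroxyl from the effect of where it sits. On these data alone, it also remains open how a methoxy group, an amine or a carboxylic acid would read in place of that hydroxyl.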